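The source may hold more compounds than are shown below. What is called first, only, known or untested is meant among the compounds shown, and "the series" means these compounds.

Among the compounds with values here, in an assay for binding affinity to Apoptosis regulator Bcl-2 (Homo sapiens), read by fluorescence polarization, with a stated time of 2 h (on this read-out higher numbers stand for weaker inhibition and lower numbers for stronger inhibition), two compounds have numbers so far. Compound 1 `Cc1c(C(=O)NCCCN2CCN(C)CC2)c(-c2cccc(N3CCN(c4ccc(NS(=O)(=O)c5cccc(OC(C)C)c5)cc4)CC3)c2)c(-c2ccc(Cl)cc2)n1C` gives 522 nM, the higher of the two, while compound 2 `Cc1c(C(=O)O)c(-c2cccc(N3CCN(c4ccc(NS(=O)(=O)c5ccc(N[C@H](CCN6CCC(O)CC6)CSc6ccccc6)c(S(=O)(=O)C(F)(F)F)c5)cc4)CC3)c2)c(-c2ccc(Cl)cc2)n1C(C)C` gives 0.8 nM; these two structures differ in many places, so only their values stand side by side. Compound 3 `Cc1c(C(=O)NCCCN2CCN(C)CC2)c(-c2cccc(N3CCN(c4ccc(NS(=O)(=O)c5cccc(S(=O)(=O)C(F)(F)F)c5)cc4)CC3)c2)c(-c2ccc(Cl)cc2)n1C` is compound 1 with a single change: (trifluoromethyl)sulfonyl in place of isopropoxy on an aromatic carbon. Compound 2 also carries a (trifluoromethyl)sulfonyl group, but its many other differences leave no direct guide. A small shift toward stronger binding is expected, a 1.7-fold lower number from compound 1 to compound 3 (0.24 log units; within the scatter), possibly still within the scatter. Compound 3 is estimated at 300 nM, within a range from 80 nM to 1200 nM.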

Compound 3, inhibition constant: 39.2 nM
Compound 3: the middle estimate sits 7.7-fold (0.88 log units) above what was measured; the measured number lies below the stated range.
By their numbers in this assay, from the lowest: compound 2; then compound 3; then compound 1.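

In this assay, (trifluoromethyl)sulfonyl in place of isopropoxy on this aromatic carbon gives a 13-fold lower number from compound 1 to compound 3 (1.12 log units; beyond the scatter), so this single change alone clearly moves the number, which the earlier comparison of compounds differing in many places could not show. The two groups differ in heavy atoms and in hydrogen-bond acceptors, but the data do not separate these differences. No available measurement explains the step. On these data alone, whether a nitrile or an amine on this carbon would give a similar number remains open. So does whether this change would have the same effect with a carboxylic acid in place of the amide chain.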